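Replacing a Bromophenyl Group in a Weak Trimethoxyphenyl Amide

The source may report more compounds than this note shows. Statements on the series, on what has been measured and on what is new or still open speak of the compounds shown alone.

Measured compounds:
compound 1, `COc1ccc(CN(C(=O)CSC(=S)N2CCc3cc(Br)ccc32)c2cc(OC)c(OC)c(OC)c2)cc1`: > 20000 nM
compound 2, `COc1cc(N(Cc2ccc(Br)cc2)C(=O)CSC(=S)N2CCN(C(=O)OC(C)(C)C)CC2)cc(OC)c1OC`: 12400 nM

Of the compounds shown here, two have been tested in a functional assay on MGC-803 cells (Homo sapiens) for inhibition, read by CCK-8 assay, with a stated time of 48 h; a lower number here means a stronger inhibitor, a higher number a weaker inhibitor. Compound 1 gives only a limit, > 20000 nM, namely (the limit of > 20000 nM in this assay, at which 1 of the 2 values shown sits). Among the compounds with values here, compound 2 is the single compound with a measured number, 12400 nM, a weak result. Compound 3 `COc1ccc(CN(C(=O)CSC(=S)N2CCN(C(=O)OC(C)(C)C)CC2)c2cc(OC)c(OC)c(OC)c2)cc1[N+](=O)[O-]` has not yet been tested. It differs from compound 2 by 4-methoxy-3-nitrophenyl in place of 4-bromophenyl on a saturated chain carbon bound to an amide-type nitrogen. Within the data shown here, no measured pair isolates this change, so its direction is unknown; the step from compound 2 to compound 3 is expected to stay within the usual scatter, a 1.2-fold higher number from compound 2 to compound 3 (0.08 log units; within the scatter). Compound 3 is therefore estimated at 15000 nM, with a range of 5000 nM to 40000 nM.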

Compound 3, half-maximal inhibitory concentration: 880 nM
For compound 3 the middle estimate is 17-fold (1.23 log units) above the measured one; the whole stated range lies above it.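

In this assay, putting 4-methoxy-3-nitrobenzyl in place of 4-bromobenzyl gives a 14-fold lower number from compound 2 to compound 3 (1.15 log units; beyond the scatter) and so shows that this position responds strongly to a change of aromatic group. Compound 1 and compound 2 differ in more than one place, so they could not show this. Nothing measured here explains why the number falls.

Going by these compounds, it stays open whether the methoxy group, the nitro group or the two together account for the step. On these data alone, how an amine or a carboxylic acid in place of the nitro group would read is also open.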